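The compounds below may be only part of what the source reports. "The series", "measured", "known", "first", "only" and "open" are said of these compounds alone.

Going by the values given here, in a functional assay on M21 cells (Homo sapiens) for antiproliferative activity, read by sulforhodamine B assay, with a stated time of 48 h (a higher number here means a weaker inhibitor, a lower number a stronger inhibitor), compound 2 (`O=C1NCCN1c1ccc(S(=O)(=O)Nc2ccccc2)cc1`) gives 200 nM, the highest number of the three measured so far and thus the weakest inhibitor among them. Compound 1 (`Cc1cccc(NS(=O)(=O)c2ccc(N3CCNC3=O)cc2)c1`) gives 69 nM. Compound 3 (`Cc1ccc(C)c(NS(=O)(=O)c2ccc(N3CCNC3=O)cc2)c1`) gives 27 nM.

Compound 4 (`CC(C)Cc1ccc(NS(=O)(=O)c2ccc(N3CCNC3=O)cc2)cc1`) has not been measured. Its difference from compound 2 is isobutyl in place of hydrogen on an aromatic carbon, para to a large group.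

The nearest evidence comes from the methyl steps. Loss of methyl gives a 2.9-fold higher number from compound 1 to compound 2 (0.46 log units; beyond the scatter), a further methyl gives a 2.6-fold lower number from compound 1 to compound 3 (0.41 log units; beyond the scatter), and the full change to 2,5-dimethylphenyl gives a 7.4-fold lower number from compound 2 to compound 3 (0.87 log units; beyond the scatter). All three are modest and beyond the scatter, and among these compounds the number falls as methyl is added. Among the compounds with values here, no measured compound carries isobutyl, so the transfer from methyl is uncertain. A modest move toward a lower number in this assay is expected.

The expected step is a 2.9-fold lower number from compound 2 to compound 4 (0.46 log units; beyond the scatter). For compound 4 the estimated value is 70 nM, with an expected range of 20 nM to 250 nM.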

Compound 4, half-maximal inhibitory concentration: > 1000 nM
Compound 4 ended at the assay's limit; the forecaster's own chance of this, stated with the estimate: 3%; middle value at least 14-fold (1.15 log units) away from the limit.
By their numbers in this assay, from the lowest: compound 3; then compound 1; then compound 2. At a limit, above all of these: compound 4.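

In this assay, compound 4 gives > 1000 nM, which is a limit of the assay and not a number. Isobutyl on an aromatic carbon, para to a large group, runs against the methyl compounds: the change gives an at least 5.0-fold higher number from compound 2 to compound 4 (0.69 log units; beyond the scatter), whereas 2,5-dimethylphenyl in place of phenyl gives a 7.4-fold lower number from compound 2 to compound 3 (0.87 log units; beyond the scatter). The fall in number with added methyl among compound 1, compound 2 and compound 3 therefore does not carry over to this group at this place, and compound 4 goes against that pattern, with the step bounded on one side only: the limit of > 1000 nM in this assay, at which 1 of the 4 values shown sits.

The compounds shown do not separate the effect of the chain from that of the place, which a methyl or an ethyl para to a large group could address. Going by these compounds, how an amine or a carboxylic acid at this carbon would compare also stays open.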